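Series notes: pyridin-4-yl in place of acetoxyphenyl

The source may report more compounds than this note shows. Statements on the series, on what has been measured and on what is new or still open speak of the compounds shown alone.

Three compounds of this series have a number in a physicochemical assay for lipophilicity, measured as octanol-water partition; a higher number here means a more lipophilic compound, a lower number a more polar compound. Compound 1 `Cc1c(NCc2nnc(COc3ccccc3)o2)c(=O)n(-c2ccccc2)n1C` gives 0.98. Compound 2 `Cc1c(NCc2nnc(-c3ccccc3O)o2)c(=O)n(-c2ccccc2)n1C` gives 1.71, and compound 3 `CC(=O)Oc1ccccc1-c1nnc(CNc2c(C)n(C)n(-c3ccccc3)c2=O)o1` gives 1.98, the highest of the three numbers. Its gap to compound 2 is within the scatter, so no order between these two is claimed; against compound 1 the difference is beyond the scatter, as a number 1.00 log units higher from compound 1 to compound 3 (beyond the scatter) shows.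

Compound 4 `Cc1c(NCc2nnc(-c3ccncc3)o2)c(=O)n(-c2ccccc2)n1C` is still to be measured in this assay. The change from compound 3 is pyridin-4-yl in place of 2-acetoxyphenyl on an aromatic carbon. The measured steps at this same aromatic carbon are a number 0.73 log units higher from compound 1 to compound 2 (beyond the scatter) and a number 1.00 log units higher from compound 1 to compound 3 (beyond the scatter), both modest and beyond the scatter, while a number 0.27 log units higher from compound 2 to compound 3 (within the scatter) stays within the scatter. For the measured compounds named here, none of these steps exchanges a ring of carbon only for a ring with a hetero atom, so the series offers no direct precedent for the entering group. The step is nonetheless expected to be larger than any measured one and downward, beyond the scatter. For compound 4 the estimate in this assay is 0.65, with a range from 0.1 to 1.2. This expectation corresponds to a number 1.33 log units lower from compound 3 to compound 4 (beyond the scatter).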

Compound 4, partition coefficient: 0.8
Compound 4: the middle estimate sits 0.15 log units below what was measured; low and high end bracket the measured number.
By their numbers in this assay, from the lowest: compounds 4 and 1 (each within the scatter of the next); then compounds 2 and 3 (each within the scatter of the next).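

In this assay, for the compounds shown here, pyridin-4-yl is the first ring with a hetero atom at this aromatic carbon, and it gives a large step (a number 1.18 log units lower from compound 3 to compound 4 (beyond the scatter)) and a modest one (a number 0.91 log units lower from compound 2 to compound 4 (beyond the scatter)), both beyond the scatter. Compounds 1 to 3 alone could be read as a pattern in which a six-membered aromatic ring held on this carbon without a linking chain gives a higher number than phenoxymethyl, but compound 4 goes against that reading, since a number 0.18 log units lower from compound 1 to compound 4 (within the scatter) stays within the scatter and places no order between the two groups. What the position tolerates in this assay therefore depends on more than having such a ring on this carbon, and no measurement at hand accounts for these steps.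

Going by these compounds, the change to compound 4 removes the 2-acetoxy or 2-hydroxy substituent and brings in the ring nitrogen at once, so the share of each in the step stays open, and a plain phenyl on this carbon would separate them. Also open is how this aromatic carbon responds to a carboxylic acid or an amine, neither of which appears among the compounds shown.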